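The source may report more compounds than this note shows. Statements on the series, on what has been measured and on what is new or still open speak of the compounds shown alone.

Measured in a functional assay on DU-145 cells (Homo sapiens) for inhibition, read by trypan blue exclusion, with a stated time of 96 h; a lower number here means a stronger inhibitor of growth, a higher number a weaker inhibitor of growth:
Compound 1 `O=C(O)c1ccc(C(=O)/C(=C\c2ccc(Cl)c([N+](=O)[O-])c2)SCc2ccc(F)cc2)cc1`: 1000 nM
Compound 2 `O=C(O)c1ccc(C(=O)/C(=C\c2ccc(Cl)c([N+](=O)[O-])c2)SCc2ccc(Br)cc2)cc1`: 500 nM
Compound 3 `O=C(O)c1ccc(C(=O)/C(=C\c2ccc(Cl)c([N+](=O)[O-])c2)SCc2ccccc2F)cc1`: 1000 nM

Compound 1 is level with compound 3, and a 2.0-fold lower number from compound 1 to compound 2 (0.30 log units; within the scatter) stays within the scatter, so the three compounds cannot be ranked. Compound 4 `CC(=O)Nc1ccc(/C=C(/SCc2ccc(F)cc2)C(=O)c2ccc(C(=O)O)cc2)cc1[N+](=O)[O-]` differs from compound 1 by acetamido in place of chloro on an aromatic carbon, with acetamido in place of chloro on an aromatic carbon, ortho to a nitro group. The steps of a 2.0-fold lower number from compound 1 to compound 2 (0.30 log units; within the scatter) and no change at the digits printed from compound 1 to compound 3 (within the scatter) both alter the group on the sulfur side, so neither touches this place. For the measured compounds named here, no measured step therefore speaks to the change directly, and no shift beyond the scatter can be predicted in this assay. The expected step is no change at the digits printed from compound 1 to compound 4 (within the scatter), though with wide uncertainty. For compound 4 the estimate is 1000 nM, with an expected range of 300 nM to 3500 nM.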

Compound 4, concentration for 50% growth inhibition: 10000 nM
Estimate against measurement, compound 4: 10-fold (1.00 log units) below; measured number above the stated range.
By their numbers in this assay, from the lowest: compounds 2, 1 and 3 (each within the scatter of the next); then compound 4.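

In this assay, the aromatic carbon ortho to a nitro group proved responsive: acetamido in place of chloro gives a 10-fold higher number from compound 1 to compound 4 (1.00 log units; beyond the scatter). This is the only step among the compounds shown that lies beyond the scatter, whereas the changes on the sulfur side all stayed within it. Nothing measured here accounts for the shift.

Only one replacement for chloro is shown at this place, so it remains open whether the higher number is particular to acetamido or extends to other groups. An amine, a methoxy group or a longer amide chain there could help to tell these apart.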